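From 3-methylpiperidin-1-yl to (2-anilinoethyl)amino on the carbonyl

The source may report more compounds than this note shows. Statements on the series, on what has been measured and on what is new or still open speak of the compounds shown alone.

Compound 1 `Cc1c(C(=O)OCCCN(C)C)oc2ccc(N(Cc3ccc(Br)cc3)S(=O)(=O)c3ccc(Br)cc3)cc12`: 28600 nM
Compound 2 `Cc1c(C(=O)NCCS(C)(=O)=O)oc2ccc(N(Cc3ccc(Br)cc3)S(=O)(=O)c3ccc(Br)cc3)cc12`: > 40000 nM (a limit of the assay)
Compound 3 `Cc1c(C(=O)N2CCCC(C)C2)oc2ccc(N(Cc3ccc(Br)cc3)S(=O)(=O)c3ccc(Br)cc3)cc12`: 19400 nM

All three results come from a functional assay on MDA-MB-231 cells (Homo sapiens) for antiproliferative activity, read by MTT assay, with a stated time of 48 h; a higher number here means a weaker inhibitor, a lower number a stronger inhibitor. Compound 3 and compound 1 cannot be told apart on these numbers: a 1.5-fold lower number from compound 1 to compound 3 (0.17 log units; within the scatter). Compound 3 stands clearly apart only from compound 2: an at least 2.0-fold lower number from compound 2 to compound 3 (0.31 log units; beyond the scatter).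

The next molecule, compound 4 `Cc1c(C(=O)NCCNc2ccccc2)oc2ccc(N(Cc3ccc(Br)cc3)S(=O)(=O)c3ccc(Br)cc3)cc12`, changes one group of compound 3: (2-anilinoethyl)amino in place of 3-methylpiperidin-1-yl on a carbonyl carbon. In words, this is (2-anilinoethyl)amino in place of 3-methylpiperidin-1-yl on a carbonyl carbon.

Going by the values given here, two measured steps bear on this change. Compound 2 also carries an amino group on that carbonyl carbon, namely (2-(methylsulfonyl)ethyl)amino, so its step to compound 3 is the closest guide, and read in reverse it points towards a higher number in this assay. The step to compound 3 from compound 1, which stayed within the scatter, shows that replacing this group need not move the number much. A small move to a higher number is therefore expected, possibly no larger than the scatter. The expected change is a 1.4-fold higher number from compound 3 to compound 4 (0.14 log units; within the scatter). The estimate for compound 4 is 27000 nM, with an expected range from 13000 nM to 40000 nM.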

Compound 4, half-maximal inhibitory concentration: > 40000 nM
Compound 4 ended at the assay's limit; the forecaster's own chance of this, stated with the estimate: 30%; at least 1.4-fold (0.17 log units) between middle value and limit.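

In this assay, the (2-anilinoethyl)amino group gives a clear loss against the 3-methylpiperidin-1-yl group on the same carbonyl carbon: an at least 2.0-fold higher number from compound 3 to compound 4 (0.31 log units; beyond the scatter). This makes it the second group with an amide hydrogen on that carbon, after the (2-(methylsulfonyl)ethyl)amino group of compound 2, to fall clearly short of compound 3, even though the two chains end in quite different groups, while the comparison with the 3-(dimethylamino)propoxy group is less decisive, as its floor does not clear the scatter: an at least 1.3-fold higher number from compound 1 to compound 4 (0.14 log units; that floor lies within the scatter). The step from compound 2 to compound 4 cannot be read, because both results are limits of the assay rather than numbers: the limit of > 40000 nM in this assay, at which 2 of the 4 values shown sit.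

On these data alone, how far compound 2 and compound 4 lie past that limit remains open, so the two chain ends cannot be ranked against each other. Also open, as far as these compounds go, is whether a plain ethylamino group, a chain ending in a carboxylic acid, or a morpholine ring on the carbonyl carbon would give a measurable number, and so whether the loss belongs to the amide hydrogen or to these particular chains.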